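The source may hold more compounds than are shown below. What is called first, only, known or untested is meant among the compounds shown, and "the series" means these compounds.

Measured so far in an assay for positive allosteric modulation of metabotropic glutamate receptor 3 (Rattus norvegicus); a lower number here means that less compound is needed, a higher number that more compound is needed for the effect:

compound 1, `COc1ccc(C(=O)O)cc1O[C@@H](C)COc1ccc(C(=O)CC(C)(C)C)c(O)c1C`: 2210 nM
compound 2, `Cc1c(O[C@@H](C)COc2ccc(F)c(C(=O)O)c2)ccc(C(=O)CC(C)(C)C)c1O`: 1120 nM
compound 3, `Cc1c(OC[C@H](C)COc2ccc(F)c(C(=O)O)c2)ccc(C(=O)CC(C)(C)C)c1O`: 651 nM

Compound 3 stands with the lowest of the three numbers. The nearest to it is compound 2, whose 1120 nM lies within the usual scatter of such measurements, so the two cannot be ranked against each other on these numbers. The furthest is compound 1, whose 2210 nM lies beyond the scatter, so compound 3 and compound 1 are separated by more than measurement noise.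

Compound 4, `Cc1c(OC[C@@H](C)COc2ccc(F)c(C(=O)O)c2)ccc(C(=O)CC(C)(C)C)c1O`, has not yet been measured. (the two compounds have the same atoms and bonds and differ only in configuration as drawn: 1 of 1 stereo elements differ; a stereocentre at a saturated chain carbon is drawn R in compound 3 and S in compound 4). Among the measured compounds no pair differs in this way, so these data carry no example of how this assay responds to a swap of configuration. Such mirror-image pairs are often told apart by an assay, sometimes by a wide margin and sometimes not at all, and the direction cannot be read from the compounds shown here. The step from compound 3 to compound 4 is expected to be a 2.0-fold higher number from compound 3 to compound 4 (0.30 log units; within the scatter), leaning toward a higher number, with a range that stretches from within the scatter to a clear separation. Compound 4 is estimated at 1300 nM, with a range from 450 nM to 4500 nM.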

Compound 4, half-maximal effective concentration: 1180 nM
Beside the measured number, compound 4's estimate is 1.1-fold (0.04 log units) above it; measured number inside the range.
By their numbers in this assay, from the lowest: compounds 3, 2, 4 and 1 (each within the scatter of the next, the first and the last beyond it).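

In this assay, swapping the stereocentre on the saturated chain from R to S gives a 1.8-fold higher number from compound 3 to compound 4 (0.26 log units; within the scatter), so the two forms cannot be ranked against each other on these numbers. The earlier compounds shown here held no pair of this kind, and this pair isolates configuration from every other structural change, because the comparison rests on one thing alone: the fact that compounds 3 and 4 differ only in the configuration as drawn At this stereocentre, then, any preference of the assay for one configuration does not rise above the noise of repeated measurements, although a gap of this size does not prove that the two forms behave identically either.

Among the compounds shown here, one pair at one stereocentre leaves open whether a swap of configuration in the chain of compound 2 would read the same way, since that chain differs from the one in compounds 3 and 4. It also leaves open whether the two configurations would separate more clearly with a larger group at the stereocentre, such as an ethyl or a phenyl group.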